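Fluoro for Ethyl: An Untested Change from Compound 2

The source may report more compounds than this note shows. Statements on the series, on what has been measured and on what is new or still open speak of the compounds shown alone.

Of the compounds shown here, three on a shared core have been measured in an ADME assay on HCT-116 cells (Homo sapiens) for cytotoxicity, read by MTT assay, with a stated time of 72 h; a higher number here means a weaker inhibitor, a lower number a stronger inhibitor. Compound 1 `CCCCCN1C(=O)C/C(=C\c2cccc(C(=O)Nc3cccc(CC)c3)c2)C1=O` gives 75300 nM, compound 2 `CCc1cccc(NC(=O)c2cccc(/C=C3\CC(=O)N(c4ccccc4)C3=O)c2)c1` gives 81200 nM, and compound 3 `CCc1cccc(NC(=O)c2cccc(/C=C3\CC(=O)N(c4ccc(C)cc4)C3=O)c2)c1` gives 41500 nM. Compound 2 holds the highest of the three numbers, but both others sit within the scatter of it: a 1.1-fold higher number from compound 1 to compound 2 (0.03 log units; within the scatter) and a 2.0-fold lower number from compound 2 to compound 3 (0.29 log units; within the scatter), as does a 1.8-fold lower number from compound 1 to compound 3 (0.26 log units; within the scatter). Compound 4 `O=C(Nc1cccc(F)c1)c1cccc(/C=C2\CC(=O)N(c3ccccc3)C2=O)c1` departs from compound 2 by one change: fluoro in place of ethyl on an aromatic carbon. Within the data shown here, no measured step touches this place; the three known steps swap the group on the amide-type nitrogen in a ring or add a methyl on an aromatic carbon there, and none left the scatter. The author therefore expects no step beyond the scatter, a 1.1-fold lower number from compound 2 to compound 4 (0.03 log units; within the scatter). Compound 4 is estimated at 75000 nM, within 30000 nM to 180000 nM.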

Compound 4, half-maximal inhibitory concentration: > 100000 nM
Compound 4 gave a limit, no number; the forecaster's own chance of this, stated with the estimate: 10%; middle value at least 1.3-fold (0.12 log units) from the limit.
By their numbers in this assay, from the lowest: compounds 3, 1 and 2 (each within the scatter of the next). At a limit, above all of these: compound 4.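

Compound 4 gives only a limit in this assay, > 100000 nM, and not a number. Among these compounds, the change from 3-ethylphenyl to 3-fluorophenyl provides the first reading at this position, an at least 1.2-fold higher number from compound 2 to compound 4 (0.09 log units; that floor lies within the scatter), so the step has a floor but no ceiling and may or may not lie beyond the scatter. Compound 4 alone among the compounds shown stands at this limit: the limit of > 100000 nM in this assay, at which 1 of the 4 values shown sits.

The compounds shown leave open how an amine, a methoxy group or a longer chain would read at this place. They also leave open whether any group here gives a number clearly lower than that of compound 2.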